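A few compounds are considered here, and "the series" means these few. Any claim that something is new, unique, unknown or untested is made for them only; others in the source may bear on it.

Working notes on the series.

Compound 1 `CCC(=O)NS(=O)(=O)c1ccc(-n2nc(C(F)(F)F)cc2-c2ccc(Br)cc2)cc1CO` carries a trifluoromethyl group on its pyrazole-type central ring; in a functional assay on the whole organism (strain Wistar) with Rattus norvegicus as the target, read by paw edema (on this read-out lower numbers stand for an effect already at smaller amounts and higher numbers for an effect only at larger amounts of compound), compound 1 gives 7.2 mg/kg. Compound 2 `CCC(=O)NS(=O)(=O)c1ccc(-n2nc(C(F)F)cc2-c2ccc(Br)cc2)cc1CO` differs from compound 1 only by hydrogen in place of fluoro on a saturated chain carbon bound to an aromatic carbon and two fluorine atoms; in this assay compound 2 gives 5.6 mg/kg. The resulting step, a 1.3-fold lower number from compound 1 to compound 2 (0.11 log units; within the scatter), is too small to be read as a real shift.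

Compound 3 `CCC(=O)OCc1cc(-n2nc(C(F)(F)F)cc2-c2ccc(OC)c(C)c2)ccc1S(N)(=O)=O` rests on a different core; the difference between the core of compound 1 and the core of compound 3 is not broken down here. In this assay compound 3 gives 10.9 mg/kg. Set against the values of compound 1 and compound 2, the value of compound 3 lies within the usual scatter of both, so no order among the three can be drawn from these numbers.

Compound 4 `CCC(=O)OCc1cc(-n2nc(C(F)F)cc2-c2ccc(OC)c(C)c2)ccc1S(N)(=O)=O`, not yet measured, stands to compound 3 as compound 2 stands to compound 1: the change is hydrogen in place of fluoro on a saturated chain carbon bound to an aromatic carbon and two fluorine atoms, and the place is the same word for word in both pairs, so this is the same change, seen in two pairs among the compounds here. Going by the values given here, the only guide to its effect is the pair of compound 1 and compound 2, where the step stayed within the scatter. Resting on a 1.3-fold lower number from compound 1 to compound 2 (0.11 log units; within the scatter), the step to compound 4 is expected to be a 1.3-fold lower number from compound 3 to compound 4 (0.11 log units; within the scatter), small and of uncertain direction. For compound 4 in this assay the estimated value is 8.5 mg/kg, with a likely range from 4.5 mg/kg to 16 mg/kg.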

Compound 4, dose for half-maximal effect: 15 mg/kg
Beside the measured number, compound 4's estimate is 1.8-fold (0.25 log units) below it; the range from low to high includes it.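

Replacing trifluoromethyl by difluoromethyl on the core of compound 3 gives, in this assay, a 1.4-fold higher number from compound 3 to compound 4 (0.14 log units; within the scatter), a step too small to be read as a real shift. Set beside the step on the core of compound 1, it shows no difference between the two cores: the same change on two cores in this assay, a 1.3-fold lower number (0.11 log units; within the scatter) from compound 1 to compound 2 and a 1.4-fold higher number (0.14 log units; within the scatter) from compound 3 to compound 4, 1.8-fold (0.25 log units) apart, within the scatter of two such steps. The change therefore carries from one core to the other in the sense that neither pair shows a shift beyond the scatter, but the directions printed for the two steps carry no meaning, and two pairs do not show that the change would be without effect on other cores in the series.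

The compounds shown leave open whether a monofluoromethyl, methyl or nitrile group in place of the trifluoromethyl group would also stay within the scatter in this assay. They also leave open whether the same small step would hold on a core carrying a carboxylic acid or an amine, since both cores here lack these groups.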